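A few compounds are considered here, and "the series" means these few. Any claim that something is new, unique, unknown or untested is made for them only; others in the source may bear on it.

Going by the values given here, in an ADME assay on L02 cells (Homo sapiens) for antiproliferative activity, read by MTT assay, with a stated time of 48 h (on this read-out higher numbers stand for weaker inhibition and lower numbers for stronger inhibition), compound 1 `CCn1c(C(=O)NCCN(C)C)ccc1C(CC)(CC)c1ccc(OCCC(O)(CC)CC)c(C)c1` gives 990 nM and is the only compound so far with a readable number. Compound 2 `C#CCCOC(=O)c1ccc(C(CC)(CC)c2ccc(OCCC(O)(CC)CC)c(C)c2)n1CC` reads > 50000 nM as a limit of the assay, not a number. Compound 3 `CCC(C)C(NC(=O)c1ccc(C(CC)(CC)c2ccc(OCCC(O)(CC)CC)c(C)c2)n1CC)C(=O)OC` reads > 50000 nM and this too is a limit. Compound 2 stands at the limit of > 50000 nM in this assay, at which 2 of the 3 values shown sit, with no number of its own.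

Next is compound 4 `CCC(C)C(NC(=O)c1ccc(C(CC)(CC)c2ccc(OCCC(O)(CC)CC)c(C)c2)n1CC)C(=O)O`, reached through (1-carboxy-2-methylbutyl)amino in place of (but-3-yn-1-yl)oxy on a carbonyl carbon with (1-carboxy-2-methylbutyl)amino in place of (but-3-yn-1-yl)oxy on a carbonyl carbon. The steps bearing on it are an at least 50-fold higher number from compound 1 to compound 2 (1.70 log units; beyond the scatter) and an at least 50-fold higher number from compound 1 to compound 3 (1.70 log units; beyond the scatter) and both are large. The closest, on the same carbonyl carbon, is a step that the two limits leave unreadable from compound 2 to compound 3 and it cannot be sized. Compound 4 also lacks the (2-(dimethylamino)ethyl)amino group, and replacing that group gave an at least 50-fold higher number from compound 1 to compound 2 (1.70 log units; beyond the scatter) so no return to readable numbers is expected. In this assay the expected step is a number no higher from compound 2 to compound 4 (the limit leaves the size open) and it is not expected to lie beyond the scatter. For compound 4 the estimated value is 50000 nM with an expected range of 15000 nM to 100000 nM and another limit is the likeliest report.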

Compound 4, half-maximal inhibitory concentration: 9990 nM
The estimate for compound 4 lay 5.0-fold (0.70 log units) above the measured number; measured number below the stated range.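

In this assay, the carbonyl carbon proves able to give a readable number without the (2-(dimethylamino)ethyl)amino group, as (1-carboxy-2-methylbutyl)amino gives an at least 5.0-fold lower number from compound 2 to compound 4 (0.69 log units; beyond the scatter). The comparison with the methyl ester is sharper, since hydrogen in place of methyl on an oxygen next to a carbonyl group alone gives an at least 5.0-fold lower number from compound 3 to compound 4 (0.69 log units; beyond the scatter). The free carboxyl side chain does not match the amine side chain, however, with a 10-fold higher number from compound 1 to compound 4 (1.00 log units; beyond the scatter), and compound 1 keeps the lowest number of the four.

From the compounds shown here alone, the true sizes of the two lower steps stay open, as compound 2 and compound 3 each read only as a limit and not as a number: the limit of > 50000 nM in this assay, at which 2 of the 4 values shown sit. Whether a sulfonic acid, or a longer chain carrying the dimethylamino group, would bring this carbonyl position closer to compound 1 remains unanswered here.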